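A few compounds are considered here, and "the series" means these few. Any claim that something is new, unique, unknown or untested is made for them only; others in the source may bear on it.

Measured so far in a functional assay on A549 cells (Homo sapiens), read by MTT assay, with a stated time of 72 h; on this read-out higher numbers stand for weaker inhibition and lower numbers for stronger inhibition:
compound 1 `Cc1ncnc2c1c(-c1cccs1)cn2[C@@H]1O[C@H](CO)[C@@H](O)[C@H]1O` gives > 20000 nM, a limit of the assay.
compound 2 `COc1ncnc2c1c(-c1cccs1)cn2[C@@H]1O[C@H](CO)[C@@H](O)[C@H]1O` gives 4850 nM.
compound 3 `CN(C)c1ncnc2c1c(-c1cccs1)cn2[C@@H]1O[C@H](CO)[C@@H](O)[C@H]1O` gives > 20000 nM, a limit of the assay.

Compound 1 thus stands only as a limit in this assay, and it shares that limit with another member of the set, as the limit of > 20000 nM in this assay, at which 2 of the 3 values shown sit, shows. Compound 4 `Cc1ncnc2c1c(I)cn2[C@@H]1O[C@H](CO)[C@@H](O)[C@H]1O` differs from compound 1 in one place: iodo in place of thiophen-2-yl on an aromatic carbon. The measured steps of an at least 4.1-fold lower number from compound 1 to compound 2 (0.61 log units; beyond the scatter) and an at least 4.1-fold higher number from compound 2 to compound 3 (0.61 log units; beyond the scatter) concern a different position on the shared core, so none of them bears on this change and no size or direction can be read from them. Since compound 1 stands at a limit, a step from it cannot be anchored either way. Compound 4 is expected at 30000 nM, within 8000 nM to 100000 nM. The expected step is a step that the limit leaves unreadable from compound 1 to compound 4.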

Compound 4, half-maximal inhibitory concentration: 12200 nM
The estimate for compound 4 lay 2.5-fold (0.39 log units) above the measured number; the range from low to high includes it.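

Among these compounds, at this position, two ring bonds from the ring nitrogen, the earlier compounds carried only thiophen-2-yl, and compound 4 gives the first measured number with another group there. In this assay, iodo in place of thiophen-2-yl gives an at least 1.6-fold lower number from compound 1 to compound 4 (0.21 log units; that floor lies within the scatter), so neither a real change nor its size is established. Compound 1 remains a limit, and it shares that limit with one other compound: the limit of > 20000 nM in this assay, at which 2 of the 4 values shown sit.

Still open, from the compounds shown here alone, is how an amine or a phenyl ring at this position would read. Also open, going by these compounds, is whether iodo would give a similar reading with methoxy in place of methyl on the shared core.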